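Swapping a chlorophenyl ether for a pyridyl ether

This account rests on a few compounds, and the source may have more. Where it says the series, first, only, none or still open, it means among the compounds named here.

Measured compounds:
compound 1, `CCCc1cc(C)c(C(=O)N=C(N)N)cc1S(C)(=O)=O`, 5.7 nM
compound 2, `Cc1cc(Sc2cccc(Cl)c2)c(S(C)(=O)=O)cc1C(=O)N=C(N)N`, 37 nM
compound 3, `Cc1cc(Oc2cccc(Cl)c2)c(S(C)(=O)=O)cc1C(=O)N=C(N)N`, 21 nM

All three were tested in a functional assay for inhibition of sodium/hydrogen exchanger (Oryctolagus cuniculus); on this read-out higher numbers stand for weaker inhibition and lower numbers for stronger inhibition. Compound 3 gives 21 nM, the second highest of the three numbers; it sits close to compound 2 at 37 nM, a gap within the scatter, while compound 1 at 5.7 nM lies further off, a step beyond the scatter.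

Compound 4, `Cc1cc(Oc2cccnc2)c(S(C)(=O)=O)cc1C(=O)N=C(N)N`, is not yet measured. It differs from compound 3 in one place: pyridin-3-yl in place of 3-chlorophenyl on an oxygen on an aromatic ring.

For the measured compounds named here, no measured step changes the aromatic ring on the oxygen itself. The nearest steps concern the group on the shared core: a 3.7-fold higher number from compound 1 to compound 3 (0.57 log units; beyond the scatter), and a 1.8-fold lower number from compound 2 to compound 3 (0.25 log units; within the scatter). These show the position accepts different groups with modest or no shifts. Going by the values given here, with no direct precedent for the ring swap, the expected step of a 1.4-fold higher number from compound 3 to compound 4 (0.15 log units; within the scatter) is small, most likely within the scatter. Compound 4 is therefore estimated at 30 nM, within the range 10 nM to 90 nM.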

Compound 4, half-maximal inhibitory concentration: 8.8 nM
Compound 4: middle estimate off by 3.4-fold (0.53 log units), on the high side; measured number below the stated range.
By their numbers in this assay, from the lowest: compounds 1 and 4 (each within the scatter of the next); then compounds 3 and 2 (each within the scatter of the next).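

In this assay, for the compounds shown here, the aromatic ring on the oxygen turns out to count: pyridin-3-yl in place of 3-chlorophenyl gives a 2.4-fold lower number from compound 3 to compound 4 (0.38 log units; beyond the scatter) and so a step beyond the scatter, on a ring that no earlier pair varied. Changing the whole group from (3-chlorophenyl)sulfanyl to (pyridin-3-yl)oxy gives a 4.2-fold lower number from compound 2 to compound 4 (0.62 log units; beyond the scatter) and is also beyond the scatter, while (pyridin-3-yl)oxy in place of propyl gives a 1.5-fold higher number from compound 1 to compound 4 (0.19 log units; within the scatter) and stays within it, so this ring-bearing group and the propyl chain cannot be told apart here. Nothing available explains why the ring change lowers the number.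

This swap removes the chlorine and adds the ring nitrogen in one step, so the compounds shown cannot separate the two changes, as an unsubstituted phenyl ring on the oxygen might. They also leave open whether pyridin-2-yl or pyridin-4-yl would read like pyridin-3-yl.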